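Dichloro for bromo on a curcumin-like bis-benzylidene ketone

The compounds below may be only part of what the source reports. "The series", "measured", "known", "first", "only" and "open" are said of these compounds alone.

Two compounds share a bis-benzylidene cyclohexanone core. Compound 1 `COc1cccc(/C=C2\CCC/C(=C\c3cccc(Cl)c3)C2=O)c1OC` and compound 2 `COc1ccc(/C=C2\CCC/C(=C\c3cccc(Br)c3)C2=O)cc1OC` differ on both aryl arms. In a functional assay on HT-1080 cells (Homo sapiens) for cytotoxicity, read by MTT assay, with a stated time of 72 h (on this read-out higher numbers stand for weaker inhibition and lower numbers for stronger inhibition), compound 1 gives 10300 nM. In the same this assay compound 2 gives 5200 nM, and the gap between compound 2 and compound 1 stays within the usual scatter, so the two numbers cannot be ordered.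

Compound 3 `COc1ccc(/C=C2\CCC/C(=C\c3ccc(Cl)c(Cl)c3)C2=O)cc1OC` has not been measured. Compared with compound 2 it shows (3,4-dichlorophenyl in place of 3-bromophenyl on a double-bonded chain carbon bound to a double-bonded ring carbon). Among the compounds with values here, no measured pair tells how such a change moves the read-out, so the expectation rests on the two values alone and on the modest size of the change. The step of a 1.3-fold lower number from compound 2 to compound 3 (0.11 log units; within the scatter) is expected to be small, most likely not beyond the scatter, with at most a mild shift toward a lower number. For compound 3 the estimate in this assay is 4000 nM, expected to fall between 1500 nM and 12000 nM.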

Compound 3, half-maximal inhibitory concentration: 3100 nM
Beside the measured number, compound 3's estimate is 1.3-fold (0.11 log units) above it; measured number inside the range.
By their numbers in this assay, from the lowest: compounds 3, 2 and 1 (each within the scatter of the next, the first and the last beyond it).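

In this assay, within the data shown here, the exchange of 3-bromophenyl for 3,4-dichlorophenyl on a double-bonded chain carbon bound to a double-bonded ring carbon amounts to a 1.7-fold lower number from compound 2 to compound 3 (0.22 log units; within the scatter) and gives the first comparison here of compounds that differ in one place. At this position, then, two chlorine atoms on the aryl ring can stand in for one bromine atom with no change that can be told from the scatter. Nothing measured here offers an explanation for this result.

The compounds shown carry only halogens on this aryl ring, so it remains open whether an amine or a carboxylic acid there would move the number beyond the scatter. Also open, going by these compounds, is whether a plain phenyl ring would do so.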